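The source may hold more compounds than are shown below. What is called first, only, known or untested is meant among the compounds shown, and "the series" means these compounds.

Three amides built on a shared core have been tested in an ADME assay (liver) for metabolic stability, with Liver microsome (Homo sapiens) as the target, using microsomes; a higher number here means that the compound lasts longer, a lower number that the compound disappears faster. Compound 1 (`Cc1nc2ccc(Cl)cn2c1C(=O)NCc1ccc(-c2ccccc2)cc1`) gives > 2 h, which is a limit and not a number. Compound 2 (`CCc1nc2cc(Cl)ccn2c1C(=O)NCc1ccc(-c2ccc(Cl)cc2)cc1`) gives > 2 h, again a limit. Compound 3 (`CCc1nc2cc(Cl)ccn2c1C(=O)NCc1ccc(-c2ccc[nH]2)cc1`) gives > 2 h, also a limit, so it has no exact value of its own. The whole set therefore comes down to the limit of > 2 h in this assay, at which 3 of the 3 values shown sit.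

Compound 4 (`CCc1nc2cc(Cl)ccn2c1C(=O)NCc1ccc(N2CCCCCC2)cc1`) has azepan-1-yl in place of the 1H-pyrrol-2-yl of compound 3, on an aromatic carbon: azepan-1-yl in place of 1H-pyrrol-2-yl on an aromatic carbon. For the measured compounds named here, the one measured step at this place is a step that the two limits leave unreadable from compound 2 to compound 3, so it offers no size to carry over. None of the three tested compounds has a seven-membered non-aromatic ring there, which makes this a move into untested ground. A modest fall from the limit seems more likely than none, but this is a cautious expectation and not a measured trend. The expected change is an at least 1.6-fold lower number from compound 3 to compound 4 (0.22 log units; that floor lies within the scatter). For compound 4 the estimated half-life is 1.2 h, with an expected range from 0.3 h to 3 h.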

Compound 4, half-life: 0.0483 h
Beside the measured number, compound 4's estimate is 25-fold (1.40 log units) above it; measured number outside the range, below it.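

This place on the six-membered aromatic ring proves highly sensitive in this assay: azepan-1-yl in place of 1H-pyrrol-2-yl gives an at least 41-fold lower number from compound 3 to compound 4 (1.61 log units; beyond the scatter), and azepan-1-yl in place of 4-chlorophenyl gives an at least 41-fold lower number from compound 2 to compound 4 (1.61 log units; beyond the scatter). For the compounds shown here, the earlier step here could not be read, so this is the first sign that a change at this place can shorten the half-life, and here a seven-membered non-aromatic ring replaces a five- or six-membered aromatic one. The set now has one real number, while the other values remain limits: the limit of > 2 h in this assay, at which 3 of the 4 values shown sit.

With only one non-aromatic ring at this place, the compounds shown cannot separate the effect of ring size from that of losing an aromatic ring. Piperidin-1-yl, morpholin-4-yl or an open-chain amine such as diethylamino remains open at this place.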